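A few compounds are considered here, and "the series" means these few. Any claim that something is new, unique, unknown or untested is made for them only; others in the source may bear on it.

The measured compounds:
compound 1, `Cc1nn(-c2ccccc2)c2nc(C(=O)N3NC(=O)/C(=C/c4ccccc4)N=C3c3ccccc3)[nH]c(=O)c12`, 14.7 nM
compound 2, `Cc1nn(-c2ccccc2)c2nc(C(=O)N3NC(=O)/C(=C/c4ccc(Cl)cc4)N=C3c3ccc(Cl)cc3)[nH]c(=O)c12`, 15 nM

In a functional assay on HCT-116 cells (Homo sapiens) for cytotoxicity, read by MTT assay, with a stated time of 48 h (on this read-out lower numbers stand for stronger inhibition and higher numbers for weaker inhibition), compound 1 gives 14.7 nM. Compound 2 gives 15 nM in this assay. Of the two numbers, compound 1 has the lower one, but its gap to compound 2 lies within the usual scatter of repeated measurements of this kind, so the two compounds cannot be told apart on what has been measured. Compound 2 carries a chlorine on each of two phenyl rings that compound 1 lacks, and the read-out stays where it was.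

Compound 3, `Cc1ccc(C2=N/C(=C\c3ccccc3)C(=O)NN2C(=O)c2nc3c(c(C)nn3-c3ccccc3)c(=O)[nH]2)cc1`, has not yet been measured in this assay. It differs from compound 1 by one change: methyl in place of hydrogen on an aromatic carbon. Going by the values given here, no step between two measured compounds matches this change, so the expectation rests on the two numbers alone. Since two chlorines added to compound 1 left the read-out unchanged in compound 2, a single methyl is expected to give no step beyond the scatter in either direction. The expected step is a 1.0-fold higher number from compound 1 to compound 3 (0.01 log units; within the scatter). Compound 3 is expected to give about 15 nM, with a range from 7 nM to 32 nM.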

Compound 3, half-maximal inhibitory concentration: 46.5 nM
Compound 3: the middle estimate sits 3.1-fold (0.49 log units) below what was measured; measured number above the stated range.
By their numbers in this assay, from the lowest: compounds 1 and 2 (each within the scatter of the next); then compound 3.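

In this assay, the change from phenyl to 4-methylphenyl gives a 3.2-fold higher number from compound 1 to compound 3 (0.50 log units; beyond the scatter), and this step lies beyond the scatter. Going by these compounds alone, it is the first evidence that this phenyl ring responds to a change at this place, para to a large group, and that a single methyl is enough to weaken the read-out by a modest step. Compound 2 could not show this because it differs from compound 1 in two places at once, which leaves the effect of either ring unresolved, and nothing at hand bears on why the methyl raises the number.

As far as these compounds go, whether a lone chlorine, a methoxy group or an amine at this same place would raise the number as methyl does remains open, as does whether a longer chain such as ethyl would raise it further. Also open, from the compounds shown here alone, is how a methyl would read on the other phenyl ring that carries a chlorine in compound 2, since this single step speaks only for the ring changed in compound 3.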